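Replacing the amino-bearing group of compound 3

The compounds below may be only part of what the source reports. "The series", "measured", "known", "first", "only" and "open" are said of these compounds alone.

compound 1 `CC(C)(C)n1cc2c(n1)C(=O)CC1(CCN(C(=O)c3cc(-c4ccccc4Cl)nc4ccccc34)CC1)O2`: 2180 nM
compound 2 `CC(C)(C)n1cc2c(n1)C(=O)CC1(CCN(C(=O)c3cc(-c4ccc(F)cc4)nc4ccccc34)CC1)O2`: 5770 nM
compound 3 `CC(C)(C)n1cc2c(n1)C(=O)CC1(CCN(C(=O)c3cc(-c4ccc(N)cc4)nc4ccccc34)CC1)O2`: 970 nM

In a functional assay on A549 cells (Homo sapiens) for inhibition, read by MTT assay, with a stated time of 72 h (on this read-out lower numbers stand for stronger inhibition and higher numbers for weaker inhibition), compound 3 gives the lowest number of the three, and the compounds differ only in the group carried on the shared core. The next compound to be measured, compound 4 `CC(C)(C)n1cc2c(n1)C(=O)CC1(CCN(C(=O)c3cc(-c4ccncc4)nc4ccccc34)CC1)O2`, has pyridin-4-yl in place of 4-aminophenyl on an aromatic carbon. Going by the values given here, no measured step makes this exact change. The closest is a 5.9-fold lower number from compound 2 to compound 3 (0.77 log units; beyond the scatter), a modest step in which amino replaces fluoro. Also relevant are a 2.2-fold lower number from compound 1 to compound 3 (0.35 log units; beyond the scatter) and a 2.6-fold higher number from compound 1 to compound 2 (0.42 log units; beyond the scatter), both modest as well. Among the compounds with values here, compound 3 is the only measured compound with an amino group, and the two without one both give higher numbers. Three compounds make a thin basis for this pattern, though none goes against it. Compound 4 also lacks the amino group, so a modest step to a higher number is expected, similar in size to the measured ones. Within the data shown here, no pyridinyl compound has been measured yet, so the range is kept wide. The estimated change is a 2.6-fold higher number from compound 3 to compound 4 (0.41 log units; beyond the scatter). For compound 4 the expected value is 2500 nM, within an estimated range of 900 nM to 7000 nM.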

Compound 4, half-maximal inhibitory concentration: 550 nM
Compound 4: the middle estimate sits 4.5-fold (0.66 log units) above what was measured, outside the stated range (below it).
By their numbers in this assay, from the lowest: compounds 4 and 3 (each within the scatter of the next); then compound 1; then compound 2.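

With pyridin-4-yl on the aromatic carbon next to the ring nitrogen, this assay gives a 1.8-fold lower number from compound 3 to compound 4 (0.25 log units; within the scatter) as the step, which lies within the scatter, so compound 3 and compound 4 cannot be told apart on this read-out. The earlier link between the amino group and the lowest number therefore does not hold as a requirement: compound 4 has no amino group and no hydrogen-bond donor in this substituent, yet stands level with compound 3. The separation from the halogen-bearing aryl groups is clear, with a 10-fold lower number from compound 2 to compound 4 (1.02 log units; beyond the scatter) as a large step and a 4.0-fold lower number from compound 1 to compound 4 (0.60 log units; beyond the scatter) as a modest one, both beyond the scatter, while no supporting measurement is available to account for these differences.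

What the compounds leave open is whether the low numbers depend on the nitrogen of pyridin-4-yl and the amino group of 4-aminophenyl, or would also be reached with a hydroxyl group or a carboxylic acid on the phenyl ring, or with a pyrimidinyl group in the same place. They also leave open whether this ranking extends beyond the one cell line shown here.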